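Moving the halogen on a weak hydroxamate series

The compounds below may be only part of what the source reports. "The series", "measured", "known", "first", "only" and "open" are said of these compounds alone.

Compound 1, `C/C(=N\NC(=S)NCCCCCC(=O)NO)c1ccc(Br)cc1`, gives only a limit in an assay on isolated protein for inhibition of histone deacetylase 8 (Homo sapiens), read by fluorescence, with a stated time of 60 min; a lower number here means a stronger inhibitor, a higher number a weaker inhibitor: > 5000 nM.
Compound 2, `C/C(=N\NC(=S)NCCCCCC(=O)NO)c1ccc(F)cc1`, likewise gives only a limit in this assay: > 5000 nM.

Compound 2 therefore stands at the edge of what this assay can report, not at a measured number, and both values shown sit at that limit (the limit of > 5000 nM in this assay, at which 2 of the 2 values shown sit). Within the data shown here, the single measured step, a step that the two limits leave unreadable from compound 1 to compound 2, is thus unreadable in both size and direction. Compound 3, `C/C(=N\NC(=S)NCCCCCC(=O)NO)c1cccc(Br)c1`, differs from compound 2 by 3-bromophenyl in place of 4-fluorophenyl on a carbon with a double bond to nitrogen. No readable step bears on this change, so nothing in the data points to a rise or a fall in this assay beyond the scatter. The expectation for compound 3 is that this assay again returns only a limit, and the estimated value is 8000 nM, within a range of 3000 nM to 30000 nM. The expected step is a step that the limit leaves unreadable from compound 2 to compound 3, no change beyond the scatter.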

Compound 3, half-maximal inhibitory concentration: > 5000 nM
Compound 3: no number, only a limit; the forecaster's own chance of this, stated with the estimate: 80%; the middle value is on the limit's open side.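

In this assay compound 3 gives > 5000 nM, which is a limit and not a number. The steps to compound 3 from compound 1 and compound 2 therefore cannot be read: the limit of > 5000 nM in this assay, at which 3 of the 3 values shown sit.

On these data alone, whether the choice of halogen or its place on the phenyl ring matters at all stays open.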